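The compounds below may be only part of what the source reports. "The series", "measured", "known", "first", "only" and "open" are said of these compounds alone.

Measured in an ADME assay on MT4 cells (Homo sapiens) for cytotoxicity, read by MTT assay; a higher number here means that more compound is tolerated, a lower number that less compound is tolerated:
- Compound 1 `Cc1cc(C)cc(S(=O)(=O)c2c(C(=O)NCc3ccccc3N)[nH]c3ccc(Cl)cc23)c1`: 46200 nM
- Compound 2 `Cc1cc(C)cc(S(=O)(=O)c2c(C(=O)NCc3cccc(O)c3)[nH]c3ccc(Cl)cc23)c1`: 27000 nM
- Compound 3 `Cc1cc(C)cc(S(=O)(=O)c2c(C(=O)NCc3cc(O)ncn3)[nH]c3ccc(Cl)cc23)c1`: > 53000 nM

Compound 3 gives > 53000 nM, which is a limit of this assay and not a number. Compound 4 `Cc1cc(C)cc(S(=O)(=O)c2c(C(=O)NCc3ccc(O)cc3)[nH]c3ccc(Cl)cc23)c1` has not been measured yet. It differs from compound 3 in one place, where 4-hydroxyphenyl stands in place of 6-hydroxypyrimidin-4-yl: 4-hydroxyphenyl in place of 6-hydroxypyrimidin-4-yl on a saturated chain carbon bound to an amide-type nitrogen.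

The most useful measured step is an at least 1.9-fold higher number from compound 2 to compound 3 (0.29 log units; that floor lies within the scatter), where 6-hydroxypyrimidin-4-yl replaced 3-hydroxyphenyl on the same chain carbon. The change here runs the other way, back to a hydroxyphenyl group. The other two steps at this place are a 1.7-fold lower number from compound 1 to compound 2 (0.23 log units; within the scatter) and an at least 1.1-fold higher number from compound 1 to compound 3 (0.05 log units; that floor lies within the scatter). Within the data shown here, none of the three goes beyond the scatter, so changing this group has not yet been seen to shift the number clearly.

Compound 2 is the closest guide, and it gives 27000 nM. A modest move toward a lower number is therefore expected, with nothing clearly beyond the scatter. The expected change is an at least 1.7-fold lower number from compound 3 to compound 4 (0.24 log units; that floor lies within the scatter). For compound 4 the estimate is 30000 nM, with an expected range from 15000 nM to 53000 nM.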

Compound 4, half-maximal cytotoxic concentration: 6250 nM
The estimate for compound 4 lay 4.8-fold (0.68 log units) above the measured number; the whole stated range lies above it.
By their numbers in this assay, from the lowest: compound 4; then compounds 2 and 1 (each within the scatter of the next). At a limit, above all of these: compound 3.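

In this assay, among these compounds, the group on the saturated chain carbon bound to an amide-type nitrogen now clearly moves the number, which no earlier step at this place had done: the change gives a 4.3-fold lower number from compound 2 to compound 4 (0.64 log units; beyond the scatter) and a 7.4-fold lower number from compound 1 to compound 4 (0.87 log units; beyond the scatter). The first of these steps is the most telling, since 3-hydroxyphenyl and 4-hydroxyphenyl are built from the same atoms, so the presence of a hydroxyphenyl group does not by itself fix the number. The swap of 6-hydroxypyrimidin-4-yl for 4-hydroxyphenyl also goes beyond the scatter, an at least 8.4-fold lower number from compound 3 to compound 4 (0.92 log units; beyond the scatter), but that size is only a floor, since the starting value is a limit and not a number: the limit of > 53000 nM in this assay, at which 1 of the 4 values shown sits.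

Going by these compounds, it remains open whether a 4-aminophenyl or 4-methoxyphenyl group on the same chain carbon would fall with compound 4 or with compounds 1 and 2, which would show how much depends on the hydroxyl itself. On these data alone, it is also open whether a longer chain between the amide-type nitrogen and the 4-hydroxyphenyl ring would keep the lower number of compound 4.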